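The compounds below may be only part of what the source reports. "The series", "measured", "known", "first", "only" and "open" are said of these compounds alone.

Measured compounds:
compound 1 `CCCCCCCC/C=C\CCCCCCCCNC(=O)Nc1c(C)cccc1C` — 160 nM
compound 2 `CCCCCCCCCCCCCCCCCCOc1c(C)cccc1C` — > 10000 nM
compound 3 `CCCCCCCCCCCCCCCCCCNC(=O)Nc1c(C)cccc1C` — 610 nM; 610 nM (2 entries)

Within the data shown here, in an assay on microsomes from intestinal mucosa for inhibition of acyl-CoA:cholesterol acyltransferase (Oryctolagus cuniculus) (a higher number here means a weaker inhibitor, a lower number a stronger inhibitor), compound 1 gives 160 nM, the only single number among the three compounds. Compound 3 gives 610 nM; 610 nM (2 entries) in this assay, measured twice. For compound 2 the assay gives only a limit, > 10000 nM, and no number; this is the case described as the limit of > 10000 nM in this assay, at which 1 of the 3 values shown sits.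

Compound 4 `CCCCCCCC/C=C\CCCCCCCCNC(=O)Nc1ccccc1` has not been measured in this assay. It differs from compound 1 in one place: phenyl in place of 2,6-dimethylphenyl on an amide-type nitrogen. Among the measured compounds shown here, no measured pair shows this change, so the step is an expectation only. The expected direction is toward a weaker inhibitor, with a step of a 7.5-fold higher number from compound 1 to compound 4 (0.88 log units; beyond the scatter) beyond the scatter. For compound 4 the estimated value in this assay is 1200 nM, expected between 300 nM and 5000 nM.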

Compound 4, half-maximal inhibitory concentration: > 5000 nM
Compound 4: only a limit was reported (the forecaster's own chance of this, stated with the estimate: 10%); middle value at least 4.1-fold (0.61 log units) away from the limit.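

Compound 4 gives no number in this assay, only a limit: the limit of > 5000 nM in this assay, at which 1 of the 4 values shown sits.

Among these compounds, this is the first comparison here between compounds that differ in one place, and replacing 2,6-dimethylphenyl with phenyl on the amide-type nitrogen gives an at least 31-fold higher number from compound 1 to compound 4 (1.49 log units; beyond the scatter). The aromatic ring stays and only its two methyl groups leave, so at this position those methyl groups matter a great deal for inhibition.

The compounds shown leave open whether a single methyl group would be enough, or whether larger groups such as isopropyl or chlorine in the same places would match compound 1. They also do not show why the methyl groups matter.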